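From pyridin-2-yl to pyridin-4-yl on compound 3

The compounds below may be only part of what the source reports. "The series", "measured", "known", "first", "only" and "open" are said of these compounds alone.

In a functional assay on A549 cells (Homo sapiens) for cytotoxicity, read by resazurin assay, with a stated time of 72 h (on this read-out lower numbers stand for stronger inhibition and higher numbers for weaker inhibition), compound 3 (`Nc1c(-c2nc3ccccc3[nH]2)cc(-c2ccccc2)n1-c1ccccn1`) reads 8000 nM on this measure. That is within the usual scatter of compound 2 (`N#Cc1cc(-c2ccccc2)n(-c2ccncc2)c1N`) at 10700 nM in the same test. Compound 1 (`N#Cc1cc(-c2ccccc2)n(-c2ccccn2)c1N`) reads 32000 nM there, a gap from compound 3 that lies beyond the scatter.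

The next compound, compound 4 (`Nc1c(-c2nc3ccccc3[nH]2)cc(-c2ccccc2)n1-c1ccncc1`), has pyridin-4-yl in place of pyridin-2-yl on an aromatic nitrogen and keeps the 1H-benzimidazol-2-yl group of compound 3.

The same exchange has been measured only once, as a 3.0-fold lower number from compound 1 to compound 2 (0.48 log units; beyond the scatter) in a pair that carries cyano where compound 3 carries 1H-benzimidazol-2-yl. The other measured step, a 4.0-fold lower number from compound 1 to compound 3 (0.60 log units; beyond the scatter) for that very replacement of cyano, shows that this group alone moves the number by a modest amount. Among the compounds with values here, with no second pair, the data cannot show whether the two changes add.

A modest move toward a lower number in this assay is therefore expected, somewhat smaller than in the cyano pair. The expected change is a 2.3-fold lower number from compound 3 to compound 4 (0.36 log units; beyond the scatter) on this estimate. Compound 4 is estimated at 3500 nM with an expected range from 1500 nM to 8500 nM on this measure.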

Compound 4, half-maximal inhibitory concentration: 1100 nM
Beside the measured number, compound 4's estimate is 3.2-fold (0.50 log units) above it; measured number outside the range, below it.
By their numbers in this assay, from the lowest: compound 4; then compounds 3 and 2 (each within the scatter of the next); then compound 1.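

In this assay, pyridin-4-yl in place of pyridin-2-yl on the aromatic nitrogen now lowers the number on a second core, a 7.3-fold lower number from compound 3 to compound 4 (0.86 log units; beyond the scatter), so this change is seen with 1H-benzimidazol-2-yl as well as with cyano, and the two steps agree: the same change on two cores in this assay, a 3.0-fold lower number (0.48 log units; beyond the scatter) from compound 1 to compound 2 and a 7.3-fold lower number (0.86 log units; beyond the scatter) from compound 3 to compound 4, 2.4-fold (0.39 log units) apart, within the scatter of two such steps

The replacement of cyano by 1H-benzimidazol-2-yl also carries over, now with pyridin-4-yl on the aromatic nitrogen, a 9.7-fold lower number from compound 2 to compound 4 (0.99 log units; beyond the scatter), and these two steps agree as well: the same change on two cores in this assay, a 4.0-fold lower number (0.60 log units; beyond the scatter) from compound 1 to compound 3 and a 9.7-fold lower number (0.99 log units; beyond the scatter) from compound 2 to compound 4, 2.4-fold (0.39 log units) apart, within the scatter of two such steps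

Within the scatter, then, the four compounds show the two changes adding, with each one lowering the number whichever form of the other group is present, which compounds 1, 2 and 3 alone could not show.

The compounds shown leave open how pyridin-3-yl or a plain phenyl group would read on the same aromatic nitrogen, so the trend rests on only two pyridine isomers. They also leave open whether the effect of the pyridine exchange would hold with a group such as a carboxamide or a carboxylic acid in place of cyano or 1H-benzimidazol-2-yl.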